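Amide nitrogen substituents on the shared core: compound 4

This account rests on a few compounds, and the source may have more. Where it says the series, first, only, none or still open, it means among the compounds named here.

Compound 1 `O=C1COc2ccc(-c3cccc(NS(=O)(=O)c4ccc(F)cc4)c3)cc2N1C1CC1` carries cyclopropyl on an amide-type nitrogen in a ring. In a functional assay on MCF7 cells (Homo sapiens) for antiproliferative activity, read by MTT assay, with a stated time of 72 h (on this read-out higher numbers stand for weaker inhibition and lower numbers for stronger inhibition), compound 1 gives > 40000 nM, which is a limit of the assay and not a number. Compound 2 `O=C1COc2ccc(-c3cccc(NS(=O)(=O)c4ccc(F)cc4)c3)cc2N1c1ccccc1` gives > 40000 nM in this assay, again a limit rather than a number. Going by the values given here, compound 3 `COc1ccc(N2C(=O)COc3ccc(-c4cccc(NS(=O)(=O)c5ccc(F)cc5)c4)cc32)cc1` is the one member with a number in this assay, 32400 nM, so it stands as the only read value among the three. The step of an at least 1.2-fold lower number from compound 1 to compound 3 (0.09 log units; that floor lies within the scatter) and the step of an at least 1.2-fold lower number from compound 2 to compound 3 (0.09 log units; that floor lies within the scatter) are both floors that lie within the scatter, and the step that the two limits leave unreadable from compound 1 to compound 2 cannot be read at all because the limit of > 40000 nM in this assay, at which 2 of the 3 values shown sit, holds both ends of it.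

Compound 4 `O=C1COc2ccc(-c3cccc(NS(=O)(=O)c4ccc(F)cc4)c3)cc2N1C1CCCCC1` brings (cyclohexyl in place of 4-methoxyphenyl on an amide-type nitrogen in a ring). The bearing steps are those of compound 1 and compound 2 toward compound 3, both small or unreadable, and the cyclopropyl analogue compound 1 sits at the limit of > 40000 nM in this assay, at which 2 of the 3 values shown sit. The expected step of a 1.2-fold higher number from compound 3 to compound 4 (0.09 log units; within the scatter) is therefore toward a higher number, or none beyond the scatter, and most likely a return to the limit. Compound 4 is estimated at 40000 nM in this assay, with a range from 15000 nM to 100000 nM.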

Compound 4, half-maximal inhibitory concentration: 21400 nM
The estimate for compound 4 lay 1.9-fold (0.27 log units) above the measured number, within the range that was stated.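

In this assay the step is a 1.5-fold lower number from compound 3 to compound 4 (0.18 log units; within the scatter), so on the amide-type nitrogen a cyclohexyl, a non-aromatic ring of carbon only, cannot be told apart from the 4-methoxyphenyl, and a readable number at this position does not depend on an aromatic ring. Against the two compounds held at the limit, the readings are an at least 1.8-fold lower number from compound 2 to compound 4 (0.27 log units; that floor lies within the scatter) and an at least 1.8-fold lower number from compound 1 to compound 4 (0.27 log units; that floor lies within the scatter), and neither floor shows that cyclohexyl differs from phenyl or from cyclopropyl beyond the scatter. The position now holds two read numbers and two limits, and no change at it has yet given a step that clears the scatter: the limit of > 40000 nM in this assay, at which 2 of the 4 values shown sit.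

As far as these compounds go, it remains open whether an aminoethyl chain, a carboxylic acid on a longer chain or a plain hydrogen on this nitrogen would move the number beyond the scatter. The compounds shown also vary only this one position, so how the number responds to changes elsewhere on the shared core stays open.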